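Arylamino in place of hydroxy on the shared core

The source may hold more compounds than are shown below. What is called first, only, known or untested is meant among the compounds shown, and "the series" means these compounds.

Measured compounds in a functional assay on A549 cells (Homo sapiens) for antiproliferative activity, read by MTT assay, with a stated time of 72 h; a lower number here means a stronger inhibitor, a higher number a weaker inhibitor:
compound 1 `O=C(C1=C(O)C(=O)N(CCCn2ccnc2)C1c1ccc(Br)cc1)c1ccccc1` — compound 1 gives 73100 nM
compound 2 `NC1=C(C(=O)c2ccccc2)C(c2ccc(Br)cc2)N(CCCn2ccnc2)C1=O` — compound 2 is reported as "not active" (no number reported), with no number
compound 3 `O=C(C1=C(Nc2ccc(I)cc2)C(=O)N(CCCn2ccnc2)C1c1ccc(Br)cc1)c1ccccc1` — compound 3 gives 24500 nM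

Compound 1 stands highest of the two numbers in this assay. Its nearest neighbour is compound 3, reached by a 3.0-fold lower number from compound 1 to compound 3 (0.47 log units; beyond the scatter), a modest step beyond the scatter. Among the measured compounds shown here, compound 2 gives no number and so sets no step.

Compound 4 `O=C(C1=C(Nc2ccc(OC(F)(F)F)cc2)C(=O)N(CCCn2ccnc2)C1c1ccc(Br)cc1)c1ccccc1` differs from compound 1 by (4-(trifluoromethoxy)phenyl)amino in place of hydroxy on a double-bonded ring carbon. For the measured compounds named here, the only measured step that bears on this is the one from hydroxy to (4-iodophenyl)amino at the same double-bonded ring carbon, a 3.0-fold lower number from compound 1 to compound 3 (0.47 log units; beyond the scatter). Compound 4 carries a (4-(trifluoromethoxy)phenyl)amino group at that carbon, so a lower number than compound 1 is expected, of roughly the same size as that step, because compound 3 gave a 3.0-fold lower number from compound 1 to compound 3 (0.47 log units; beyond the scatter). Going by the values given here, nothing among the measured compounds separates one 4-substituted phenylamino from another, so the expected step is taken as a 2.9-fold lower number from compound 1 to compound 4 (0.47 log units; beyond the scatter). For compound 4 the estimated value in this assay is 25000 nM, expected to fall between 8000 nM and 70000 nM.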

Compound 4, half-maximal inhibitory concentration: 20800 nM
For compound 4 the middle estimate is 1.2-fold (0.08 log units) above the measured one, and the stated range covers the measured number.
By their numbers in this assay, from the lowest: compounds 4 and 3 (each within the scatter of the next); then compound 1.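

In this assay, a second 4-substituted phenylamino group on the double-bonded ring carbon gives a 3.5-fold lower number from compound 1 to compound 4 (0.55 log units; beyond the scatter) and so repeats the direction of the hydroxy replacement, which until now rested on compound 3 alone. Trifluoromethoxy in place of iodo on the aromatic carbon gives a 1.2-fold lower number from compound 3 to compound 4 (0.07 log units; within the scatter) and leaves the two arylamino compounds unseparated, so in this pair the lower number than compound 1 does not depend on which of the two substituents is present. Compound 2, with amino at the same ring carbon, is reported as "not active" and has no number, so the shift to a lower number is seen only for the two arylamino compounds, and no data given here bear on why these steps arise.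

Still open, as far as these compounds go, is whether an unsubstituted phenylamino, a benzylamino or a phenylamino bearing a carboxylic acid or a dimethylamino group at the 4-position would separate from compounds 3 and 4 in this assay by more than the scatter. Also open, from the compounds shown here alone, is whether the same replacement holds when the 3-(1H-imidazol-1-yl)propyl group gives way to a longer chain or a morpholine-bearing chain.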